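Trimming a Thioether Side Chain: Expected Antiproliferative Shift

The source may report more compounds than this note shows. Statements on the series, on what has been measured and on what is new or still open speak of the compounds shown alone.

Of the compounds shown here, two sharing one core have been measured. Compound 1 `OCC#CCSc1cnc2ccccc2c1SCC#CCCl` gives 43.4 ug/mL in a functional assay on B16 cells (Mus musculus) for antiproliferative activity, with a stated time of 72 h; on this read-out higher numbers stand for weaker inhibition and lower numbers for stronger inhibition. Compound 2 `C#CCSc1cnc2ccccc2c1SCC#CCCl` gives 52.8 ug/mL in this assay. Compound 2 stands as the highest of the two numbers shown, though its nearest neighbour, compound 1, is separated from it only by a 1.2-fold higher number from compound 1 to compound 2 (0.09 log units; within the scatter). This single step, hydrogen in place of hydroxymethyl on a triple-bonded carbon, thus leaves the read-out essentially where it was.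

Compound 3 `CSc1cnc2ccccc2c1SCC#CCCl` has not yet been measured in this assay. It differs from compound 2 by hydrogen in place of ethynyl on a saturated chain carbon bound to a sulfur; cut one bond further out, the change reads propargyl to methyl, propargylsulfanyl to methylsulfanyl. Going by the values given here, the one measured step bears on this change only in that it also shortens the same side chain, and that step was within the scatter. With so little to go on, compound 3 is expected to show a step of a 1.1-fold higher number from compound 2 to compound 3 (0.06 log units; within the scatter), a slight move toward weaker inhibition that may well fall within the scatter. The estimate for compound 3 is 60 ug/mL, with a range from 30 ug/mL to 120 ug/mL.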

Compound 3, concentration for 50% inhibition: 16.9 ug/mL
Estimate against measurement, compound 3: 3.6-fold (0.55 log units) above; the whole stated range lies above it.
By their numbers in this assay, from the lowest: compound 3; then compounds 1 and 2 (each within the scatter of the next).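

Going by these compounds alone, at this position, on a saturated chain carbon bound to a sulfur, the change of propargyl to methyl gives the first step beyond the scatter in this assay (a 3.1-fold lower number from compound 2 to compound 3 (0.49 log units; beyond the scatter)), a modest move toward stronger inhibition. The same holds when the whole 3-hydroxyprop-1-yn-1-yl group gives way to hydrogen (a 2.6-fold lower number from compound 1 to compound 3 (0.41 log units; beyond the scatter)), so compound 3 stands apart from both compounds that carry a triple bond in this chain, whereas removing only the outer hydroxymethyl had left the read-out within the scatter (a 1.2-fold higher number from compound 1 to compound 2 (0.09 log units; within the scatter)). Nothing available explains why the shorter methylsulfanyl chain goes with the lower number, and no supporting measurement bears on this result.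

The three compounds leave open whether the shift depends on losing the triple bond or on shortening the chain, a question that an ethyl, propyl or allyl group at this sulfur would address. They also leave open how a bare thiol, or a chain ending in an amine or a carboxylic acid, would read in this assay on the same core.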